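The source may hold more compounds than are shown below. What is called first, only, known or untested is meant among the compounds shown, and "the series" means these compounds.

Measured in an ADME assay on HEK293 cells (Homo sapiens) for cytotoxicity, read by MTT assay, with a stated time of 48 h (a lower number here means a stronger inhibitor, a higher number a weaker inhibitor), so far:

compound 1 `CCS(=O)(=O)Nc1ccc(NC(=O)c2cccc(C(F)(F)F)c2)cc1C` gives 210000 nM
compound 2 `Cc1cc(NC(=O)c2cccc(C(F)(F)F)c2)ccc1NS(=O)(=O)C(F)(F)F` gives 131000 nM
compound 3 `Cc1cc(NC(=O)c2cc(C(F)(F)F)cc(C(F)(F)F)c2)ccc1NS(=O)(=O)C(F)(F)F` gives 182000 nM

Compound 2 holds the lowest of the three numbers, yet both gaps to its neighbours lie within the scatter, so the three measured compounds are not separated from one another in this assay. The two single-point steps among them are small: a 1.6-fold lower number from compound 1 to compound 2 (0.20 log units; within the scatter), and a 1.4-fold higher number from compound 2 to compound 3 (0.14 log units; within the scatter). Neither change, whether on the sulfonyl sulfur or on an aromatic carbon, moved the read-out beyond what repeated measurement would show.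

Compound 4 `O=C(Nc1ccc(NS(=O)(=O)C(F)(F)F)c(Cl)c1)c1cccc(C(F)(F)F)c1` is not yet measured. It differs from compound 2 by chloro in place of methyl on an aromatic carbon. For the measured compounds named here, no measured step touches this exchange directly; the nearest analogy is the other aromatic-carbon change, a 1.4-fold higher number from compound 2 to compound 3 (0.14 log units; within the scatter), which stayed within the scatter, and the sulfonyl change did the same. On the numbers shown there is no basis for expecting a step in this assay beyond the scatter in either direction.

Compound 4 is therefore estimated at 130000 nM, with a range from 60000 nM to 280000 nM. The expected step is a 1.0-fold lower number from compound 2 to compound 4 (0.00 log units; within the scatter), taken as no real movement.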

Compound 4, half-maximal inhibitory concentration: 210000 nM
Compound 4: the middle estimate sits 1.6-fold (0.21 log units) below what was measured, and the stated range covers the measured number.
By their numbers in this assay, from the lowest: compounds 2, 3, 1 and 4 (each within the scatter of the next).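

In this assay, compound 1, compound 2 and compound 3 all carry methyl on the aromatic carbon ortho to a ((trifluoromethyl)sulfonyl)amino group, so they gave no reading of this position; compound 4 supplies the first, with chloro in place of methyl giving a 1.6-fold higher number from compound 2 to compound 4 (0.20 log units; within the scatter) in this comparison. A third site of change therefore joins the sulfonyl sulfur and the other aromatic carbon, and all the single-place steps shown at these three sites lie within the scatter. Nothing accompanying these numbers bears on why this exchange leaves the read-out unseparated.

On these data alone, the methyl-to-chloro exchange is the only one read at this position, so it remains open whether an amine, a carboxylic acid or a longer alkyl chain there would give a step beyond the scatter. With all four compounds unseparated in this assay, the compounds shown also leave open which part of the shared core, if any, governs this read-out, and whether chloro would give the same result alongside an ethyl group on the sulfonyl sulfur.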